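The source may report more compounds than this note shows. Statements on the series, on what has been measured and on what is new or still open speak of the compounds shown alone.

Series notes. The shared core of compound 1 `COc1ccc(OC)c(/C=C/C(=O)Nc2cc3c(Nc4ccc(F)c(Cl)c4)ncnc3cc2O[C@H]2CCOC2)c1` carries varying aryl groups on the double-bonded chain carbon bound to a double-bonded chain carbon. In a functional assay on PC-3 cells (Homo sapiens) for cytotoxicity, read by MTT assay, with a stated time of 72 h (on this read-out higher numbers stand for weaker inhibition and lower numbers for stronger inhibition), compound 1 gives 8730 nM. Compound 2 `O=C(/C=C/c1ccc([N+](=O)[O-])cc1)Nc1cc2c(Nc3ccc(F)c(Cl)c3)ncnc2cc1O[C@H]1CCOC1` gives 22800 nM in this assay, and compound 3 `O=C(/C=C/c1ccc(Br)cc1)Nc1cc2c(Nc3ccc(F)c(Cl)c3)ncnc2cc1O[C@H]1CCOC1` gives 28200 nM. Compound 3 thus holds the highest of the three numbers; the step of a 1.2-fold higher number from compound 2 to compound 3 (0.09 log units; within the scatter) is within the scatter, while a 3.2-fold higher number from compound 1 to compound 3 (0.51 log units; beyond the scatter) lies beyond it. Compound 4 `O=C(/C=C/c1ccc(F)cc1Cl)Nc1cc2c(Nc3ccc(F)c(Cl)c3)ncnc2cc1O[C@H]1CCOC1` differs from compound 3 by 2-chloro-4-fluorophenyl in place of 4-bromophenyl on a double-bonded chain carbon bound to a double-bonded chain carbon. The steps bearing on this are a 1.2-fold higher number from compound 2 to compound 3 (0.09 log units; within the scatter) and a 2.6-fold higher number from compound 1 to compound 2 (0.42 log units; beyond the scatter), both exchanges of the aryl group on that chain carbon, one within the scatter, the other modest. The expected step is a 1.3-fold lower number from compound 3 to compound 4 (0.11 log units; within the scatter). For compound 4 the estimate is 22000 nM, with a range from 9000 nM to 55000 nM.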

Compound 4, half-maximal inhibitory concentration: 7150 nM
Compound 4: middle estimate off by 3.1-fold (0.49 log units), on the high side; measured number outside the range, below it.
By their numbers in this assay, from the lowest: compounds 4 and 1 (each within the scatter of the next); then compounds 2 and 3 (each within the scatter of the next).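

Changes at this aryl group are not confined to the small step seen between the two 4-substituted phenyl groups: 2-chloro-4-fluorophenyl gives a 3.9-fold lower number from compound 3 to compound 4 (0.60 log units; beyond the scatter) against 4-bromophenyl and a 3.2-fold lower number from compound 2 to compound 4 (0.50 log units; beyond the scatter) against 4-nitrophenyl. Against 2,5-dimethoxyphenyl it gives a 1.2-fold lower number from compound 1 to compound 4 (0.09 log units; within the scatter), so among these four compounds, 2-chloro-4-fluorophenyl and 2,5-dimethoxyphenyl stand together, apart from 4-bromophenyl and 4-nitrophenyl. Nothing available accounts for this separation. Open, from the compounds shown here alone, is how an aryl group bearing an amine or a carboxylic acid would compare on this chain carbon.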